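The source may hold more compounds than are shown below. What is called first, only, known or untested is meant among the compounds shown, and "the series" means these compounds.

Measured so far:
compound 1 `COc1ccccc1N1CCN(CCCNc2ncccc2C(=O)N(C)C)CC1`: 1.59 nM
compound 2 `CN(C)C(=O)c1cccnc1NCCCN1CCN(c2ccccc2OCC(F)(F)F)CC1`: 0.1 nM

Among the compounds with values here, in a functional assay for antagonist activity at Alpha-1A adrenergic receptor (Oryctolagus cuniculus) (a higher number here means weaker binding, a lower number tighter binding), compound 2 holds the lowest of the two numbers; the one measured step, a 16-fold lower number from compound 1 to compound 2 (1.20 log units; beyond the scatter), is large and separates it from compound 1. Compound 3 `CN(C)C(=O)c1cccnc1NCCCN1CCN(c2ccccc2-c2ncco2)CC1` differs from compound 2 by 1,3-oxazol-2-yl in place of 2,2,2-trifluoroethoxy on an aromatic carbon. Within the data shown here, no measured step bears directly on this exchange; the step from compound 1 to compound 2 concerns a different change at the same place and shows only that this place moves the number strongly. A moderate rise is expected, a 5.0-fold higher number from compound 2 to compound 3 (0.70 log units; beyond the scatter), with wide uncertainty. Compound 3 is estimated at 0.5 nM in this assay, range 0.1 nM to 3 nM.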

Compound 3, dissociation constant: 0.316 nM
Compound 3: the middle estimate sits 1.6-fold (0.20 log units) above what was measured; the range from low to high includes it.
By their numbers in this assay, from the lowest: compound 2; then compound 3; then compound 1.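

In this assay, this aromatic carbon also tolerates a ring: 1,3-oxazol-2-yl in place of 2,2,2-trifluoroethoxy gives a 3.2-fold higher number from compound 2 to compound 3 (0.50 log units; beyond the scatter) and, in place of methoxy, gives a 5.0-fold lower number from compound 1 to compound 3 (0.70 log units; beyond the scatter) in the other direction. The one five-membered aromatic ring therefore places compound 3 between compound 2 and compound 1, with both steps beyond the scatter. No available evidence accounts for either step.

Open, going by these compounds, is whether an amine, a carboxylic acid or a longer chain on this aromatic carbon would give a number nearer that of compound 2 or of compound 1.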